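The source may hold more compounds than are shown below. What is called first, only, known or untested is meant among the compounds shown, and "the series" means these compounds.

In an ADME assay on HEp-2 cells (Homo sapiens) for cytotoxicity (a lower number here means that less compound is tolerated, a higher number that more compound is tolerated), compound 2 `Cc1ccc(NC(=O)[C@@H]2CCCN2S(=O)(=O)c2cccc3cccnc23)cc1` gives 31700 nM, the second highest of three numbers. Compound 1 `Cc1cccc(NC(=O)[C@@H]2CCCN2S(=O)(=O)c2cccc3cccnc23)c1` gives 25500 nM in this assay, and compound 3 `COc1ccc(C)c(NC(=O)[C@@H]2CCCN2S(=O)(=O)c2cccc3cccnc23)c1` gives 44200 nM. Compound 4 `Cc1ccc(Cl)c(NC(=O)[C@@H]2CCCN2S(=O)(=O)c2cccc3cccnc23)c1` differs from compound 2 in one place: 2-chloro-5-methylphenyl in place of 4-methylphenyl on an amide-type nitrogen. The three measured steps all swap the group on that same amide-type nitrogen and all stay within the scatter: a 1.2-fold higher number from compound 1 to compound 2 (0.09 log units; within the scatter), a 1.7-fold higher number from compound 1 to compound 3 (0.24 log units; within the scatter) and a 1.4-fold higher number from compound 2 to compound 3 (0.14 log units; within the scatter). For the measured compounds named here, no step with a chlorine-bearing group has been measured, so the expectation rests on these three alone. On that basis the step to compound 4 is expected to stay within the scatter, a 1.0-fold higher number from compound 2 to compound 4 (0.00 log units; within the scatter). For compound 4 the estimate in this assay is 32000 nM, expected to fall between 14000 nM and 70000 nM.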

Compound 4, half-maximal cytotoxic concentration: > 50000 nM
Compound 4 ended at the assay's limit; the forecaster's own chance of this, stated with the estimate: 10%; middle value at least 1.5-fold (0.19 log units) from the limit.
By their numbers in this assay, from the lowest: compounds 1, 2 and 3 (each within the scatter of the next). At a limit, above all of these: compound 4.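

In this assay compound 4 stands at a limit of the assay, not at a number: the limit of > 50000 nM in this assay, at which 1 of the 4 values shown sits. For the compounds shown here, this gives the first reading of a chlorine-bearing group on the amide-type nitrogen, and it brings no lower number. Yet an at least 1.5-fold higher number from compound 2 to compound 4 (0.19 log units; that floor lies within the scatter) and an at least 1.1-fold higher number from compound 3 to compound 4 (0.05 log units; that floor lies within the scatter) and an at least 1.9-fold higher number from compound 1 to compound 4 (0.29 log units; that floor lies within the scatter) are floors only, so none of them shows a change beyond the scatter.

As far as these compounds go, how far compound 4 lies past its limit stays open. So does whether an amine or a carboxylic acid in place of the chloro group would keep the number at that limit.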